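Chloro furan nucleosides: furan-3-yl in place of furan-2-yl

This account rests on a few compounds, and the source may have more. Where it says the series, first, only, none or still open, it means among the compounds named here.

Values so far in a functional assay on A549 cells (Homo sapiens), read by sulforhodamine B assay, with a stated time of 5 days (on this read-out lower numbers stand for stronger inhibition of growth and higher numbers for weaker inhibition of growth), are as follows
- Compound 1 `OC[C@H]1O[C@@H](n2cc(F)c3c(-c4ccco4)ncnc32)[C@H](O)[C@@H]1O` gives 110 nM
- Compound 2 `OC[C@H]1O[C@@H](n2cc(Cl)c3c(-c4ccco4)ncnc32)[C@H](O)[C@@H]1O` gives > 10000 nM as a limit of the assay

Compound 2 stands at the limit of > 10000 nM in this assay, at which 1 of the 2 values shown sits, and so has a limit and no number. The next compound to be read is compound 3 `OC[C@H]1O[C@@H](n2cc(Cl)c3c(-c4ccoc4)ncnc32)[C@H](O)[C@@H]1O`, where the change is furan-3-yl in place of furan-2-yl on an aromatic carbon and the chloro group stays.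

Going by the values given here, the only measured step is an at least 90-fold higher number from compound 1 to compound 2 (1.95 log units; beyond the scatter) and it is large, but it concerns chloro in place of fluoro on an aromatic carbon. No exchange of furan-2-yl and furan-3-yl has been measured, so the size of this change cannot be read from the series. Compound 3 keeps the chloro group of the large step of an at least 90-fold higher number from compound 1 to compound 2 (1.95 log units; beyond the scatter) in this assay, so a return to the level of compound 1 is not expected. Any measurable change is expected to be modest and towards a lower number, and another limit is quite possible. The expected step is an at least 2.0-fold lower number from compound 2 to compound 3 (0.30 log units; that floor lies within the scatter) as a rough estimate. For compound 3 the estimated value is 5000 nM with 500 nM to 10000 nM as the expected range.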

Compound 3, concentration for 50% growth inhibition: 1100 nM
Compound 3: the middle estimate sits 4.5-fold (0.66 log units) above what was measured; low and high end bracket the measured number.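

In this assay, with the chloro group kept, the way the furan is joined to the aromatic carbon of the six-membered aromatic ring with 2 nitrogen matters: furan-3-yl in place of furan-2-yl gives an at least 9.0-fold lower number from compound 2 to compound 3 (0.95 log units; beyond the scatter). The entering and leaving groups have the same atoms and the same counts of hydrogen-bond donors and acceptors, so only the joining of the furan separates compound 2 from compound 3, whereas the earlier step changed the halogen and left the furan untouched. The step is a floor and its full size cannot be read, because compound 2 has a limit and no number: the limit of > 10000 nM in this assay, at which 1 of the 3 values shown sits.

As far as these compounds go, compound 1 and compound 3 differ in two places and are not compared here, so it stays open whether furan-3-yl would shift the number in the same direction with the fluoro group in place. Also open is how this aromatic carbon responds to a group other than a furan, such as a thiophene, an amine or a longer alkyl chain, since the compounds shown carry only the two furans there.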